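Bromo for Fluoro Next to the Ring Nitrogen, Again

The source may report more compounds than this note shows. Statements on the series, on what has been measured and on what is new or still open speak of the compounds shown alone.

Compound 1, `Fc1ncc(OC[C@@H]2CCN2)cc1-c1cccnc1`: 0.066 nM
Compound 2, `Brc1ncc(OC[C@@H]2CCN2)cc1-c1cccnc1`: 0.0066 nM
Compound 3, `Fc1cc(/C=C/c2cc(OC[C@@H]3CCN3)cnc2Cl)ccn1`: 0.0031 nM

In an assay on membranes from brain with Neuronal acetylcholine receptor; alpha4/beta2 (Rattus norvegicus) as the target (a higher number here means a weaker inhibitor, a lower number a stronger inhibitor), compound 1 gives 0.066 nM, and compound 2, which carries bromo in place of fluoro on an aromatic carbon, gives 0.0066 nM. Among the compounds with values here, that step, a 10-fold lower number from compound 1 to compound 2 (1.00 log units; beyond the scatter), is the one measured precedent. Compound 3 gives 0.0031 nM; how its core differs from that of compound 1 is not broken down here.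

Compound 4, `Clc1ncc(OC[C@@H]2CCN2)cc1/C=C/c1ccnc(Br)c1`, carries the same kind of change, (bromo in place of fluoro on an aromatic carbon). The surroundings differ: in compound 2 the bromo stands ortho to a pyridin-3-yl group and para to a (azetidin-2-yl)methoxy group, whereas in compound 4 it stands meta to a large group. Because a 10-fold lower number from compound 1 to compound 2 (1.00 log units; beyond the scatter), a lower number is expected, but the step is estimated more cautiously as a 2.6-fold lower number from compound 3 to compound 4 (0.41 log units; beyond the scatter). Compound 4 is therefore estimated at 0.0012 nM, between 0.0003 nM and 0.006 nM.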

Compound 4, inhibition constant: 0.0052 nM
The estimate for compound 4 lay 4.3-fold (0.64 log units) below the measured number; measured number inside the range.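

Replacing 2-fluoropyridin-4-yl with 2-bromopyridin-4-yl gives a 1.7-fold higher number from compound 3 to compound 4 (0.22 log units; within the scatter) in this assay, so the two halogens cannot be told apart on this core. The size of the change does not carry over from one core to the other: the same change on two cores in this assay, a 10-fold lower number (1.00 log units; beyond the scatter) from compound 1 to compound 2 and a 1.7-fold higher number (0.22 log units; within the scatter) from compound 3 to compound 4, 17-fold (1.22 log units) apart, beyond the scatter of two such steps. These two pairs show that the earlier step is no safe guide on this second core, but they do not show which difference between the cores sets the two steps apart, or how the change would read on any further core.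

The compounds shown leave open how a methyl group or a nitrile in place of the halogen would read in this assay. They also leave open whether either such group would follow the same course on both cores.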